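Fluorine position on the shared core: cytotoxicity notes

This account rests on a few compounds, and the source may have more. Where it says the series, first, only, none or still open, it means among the compounds named here.

Compound 2 `N#Cc1c(-c2cccc(F)c2)c(C#N)c(=O)n(/N=C/c2cn(-c3ccccc3)nc2-c2ccccc2)c1N` carries a 3-fluorophenyl group on the shared core. In an ADME assay on HeLa cells (Homo sapiens) for cytotoxicity, read by MTT assay (a higher number here means a weaker inhibitor, a lower number a stronger inhibitor), compound 2 gives > 200 ug/mL, which is a limit of the assay and not a number. Its unfluorinated parent is compound 1 `N#Cc1c(-c2ccccc2)c(C#N)c(=O)n(/N=C/c2cn(-c3ccccc3)nc2-c2ccccc2)c1N`. In this assay compound 1 gives > 200 ug/mL, again a limit. Among the compounds with values here, the step that the two limits leave unreadable from compound 1 to compound 2 thus cannot be sized; the only evidence is the limit of > 200 ug/mL in this assay, at which 2 of the 2 values shown sit. Compound 3 `N#Cc1c(-c2ccc(F)cc2)c(C#N)c(=O)n(/N=C/c2cn(-c3ccccc3)nc2-c2ccccc2)c1N` differs from compound 2 by 4-fluorophenyl in place of 3-fluorophenyl on an aromatic carbon. Within the data shown here, the fluoro-for-hydrogen step is the one measured step that bears on this change, and it is unreadable, so nothing beyond the scatter is expected in this assay for compound 3, the result most probably sitting at the same limit. The expected step that the limit leaves unreadable from compound 2 to compound 3 is none beyond the scatter. Compound 3 is estimated at 250 ug/mL, with a range from 150 ug/mL to 600 ug/mL.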

Compound 3, half-maximal inhibitory concentration: > 200 ug/mL
Compound 3 was reported as a limit; the forecaster's own chance of this, stated with the estimate: 85%; the middle value lies beyond the limit too.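

In this assay, within the data shown here, compound 3 gives > 200 ug/mL, a limit and not a number, so no step from compound 1 or compound 2 to compound 3 can be read. The compounds shown leave open whether compound 1, compound 2 and compound 3 differ at all, and the only evidence remains: the limit of > 200 ug/mL in this assay, at which 3 of the 3 values shown sit.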